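The source may hold more compounds than are shown below. What is called first, only, known or untested is meant among the compounds shown, and "the series" means these compounds.

Compound 1 `CC1(C)[C@H]2CC[C@]1(C)N(Cc1cn(-c3ccccc3Br)nn1)C(=O)C2`: 140 nM
Compound 2 `CC1(C)[C@H]2CC[C@]1(C)N(Cc1cn(-c3ccccc3Cl)nn1)C(=O)C2`: 40 nM
Compound 3 `CC1(C)[C@H]2CC[C@]1(C)N(Cc1cn(-c3cccc(Cl)c3)nn1)C(=O)C2`: 50 nM

In a functional assay on OVCAR-3 cells (Homo sapiens) for inhibition, read by MTT assay, with a stated time of 24 h (a higher number here means a weaker inhibitor, a lower number a stronger inhibitor), compound 2 gives the lowest number of the three; compound 3 lies within the scatter of it, and only compound 1 lies beyond it. Compound 4 `CC1(C)[C@H]2CC[C@]1(C)N(Cc1cn(-c3cccc(Br)c3)nn1)C(=O)C2` brings the change (3-bromophenyl in place of 2-chlorophenyl on an aromatic nitrogen). Among the compounds with values here, two measured steps bear on it: a 1.3-fold higher number from compound 2 to compound 3 (0.10 log units; within the scatter), and a 3.5-fold lower number from compound 1 to compound 2 (0.54 log units; beyond the scatter). Moving from 2-chlorophenyl to 3-chlorophenyl changed little, whereas replacing 2-bromophenyl with 2-chlorophenyl lowered the number by a modest amount. Reversing that halogen change should therefore raise the number, and a modest step up is expected, a 3.3-fold higher number from compound 2 to compound 4 (0.51 log units; beyond the scatter). Compound 4 is accordingly estimated at 130 nM, with a range from 50 nM to 320 nM.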

Compound 4, half-maximal inhibitory concentration: 30 nM
Estimate against measurement, compound 4: 4.3-fold (0.64 log units) above, outside the stated range (below it).
By their numbers in this assay, from the lowest: compounds 4, 2 and 3 (each within the scatter of the next); then compound 1.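

In this assay the step of a 4.7-fold lower number from compound 1 to compound 4 (0.67 log units; beyond the scatter) shows that the higher number of compound 1 goes with 2-bromophenyl, not with bromo as such. The other two steps, a 1.3-fold lower number from compound 2 to compound 4 (0.12 log units; within the scatter) and a 1.7-fold lower number from compound 3 to compound 4 (0.22 log units; within the scatter), both leave compound 4 level with its relatives. The swap between bromo and chloro therefore does not carry over from the 2-substituted phenyl to the 3-substituted phenyl: the same change on two cores in this assay, a 3.5-fold lower number (0.54 log units; beyond the scatter) from compound 1 to compound 2 and a 1.7-fold higher number (0.22 log units; within the scatter) from compound 4 to compound 3, 5.8-fold (0.77 log units) apart, beyond the scatter of two such steps.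

From the compounds shown here alone, whether fluoro, methoxy or an amine on this phenyl ring would follow the same pattern stays open.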